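The source may hold more compounds than are shown below. What is called first, only, known or untested is meant among the compounds shown, and "the series" means these compounds.

Measured compounds:
Compound 1 `COC(=O)/C=C/c1cccc(N(Cc2ccc(Br)cc2)C(=O)C2CCCCC2)c1` — in an assay on isolated protein with Bile acid receptor (Homo sapiens) as the target (a higher number here means that more compound is needed for the effect, a lower number that less compound is needed), compound 1 gives > 1000 nM, which is a limit of the assay.
Compound 2 `COC(=O)/C=C/c1cccc(N(Cc2cccc(OC)c2)C(=O)C2CCCCC2)c1` — in this assay compound 2 gives > 1000 nM, likewise a limit of the assay.

Compound 2 stands at the limit, where both values shown sit (the limit of > 1000 nM in this assay, at which 2 of the 2 values shown sit). For the measured compounds named here, the single measured step, a step that the two limits leave unreadable from compound 1 to compound 2, is therefore not readable in size. Compound 3 `COC(=O)/C=C/c1cccc(N(Cc2cc(OC)cc(OC)c2)C(=O)C2CCCCC2)c1` differs from compound 2 by methoxy in place of hydrogen on an aromatic carbon. Going by the values given here, no measured step reads on this change, and nothing gives a number away from the limit. Compound 3 is therefore expected to remain near the limit, the expected step being a step that the limit leaves unreadable from compound 2 to compound 3. The estimate for compound 3 is 3000 nM, with a range from 700 nM to 20000 nM.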

Compound 3, half-maximal effective concentration: 606 nM
The estimate for compound 3 lay 5.0-fold (0.69 log units) above the measured number; the measured number lies below the stated range.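

In this assay compound 3 is the only compound shown with a number rather than a limit, so a second methoxy, giving 3,5-dimethoxyphenyl, is the one change here that yields a value inside the assay's range. Methoxy in place of hydrogen gives an at least 1.6-fold lower number from compound 2 to compound 3 (0.21 log units; that floor lies within the scatter) and 3,5-dimethoxyphenyl in place of 4-bromophenyl gives an at least 1.6-fold lower number from compound 1 to compound 3 (0.21 log units; that floor lies within the scatter) as minimum sizes only. The step from compound 1 to compound 2 cannot be read.

As far as these compounds go, whether a hydroxy group, an ethoxy group or an amine at this place would match the second methoxy stays open. The true size of both steps also stays open: the limit of > 1000 nM in this assay, at which 2 of the 3 values shown sit.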